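Two aryl sulfonamide benzylamides and a third combining their pieces

The compounds below may be only part of what the source reports. "The series", "measured", "known", "first", "only" and "open" are said of these compounds alone.

Measured so far:
compound 1, `Cc1cccc(S(=O)(=O)NCc2ccc(CNC(=O)c3cccnc3)cc2)c1`, 10 nM
compound 2, `Cc1ccccc1C(=O)NCc1ccc(CNS(=O)(=O)c2ccc(F)cc2)cc1`, 10 nM

In an assay on MDA-MB-231 cells for displacement of a labelled ligand from C-X-C chemokine receptor type 4 (Homo sapiens), read by fluorescence and microscopy, with stated times of 10 min and 30 min (on this read-out higher numbers stand for an effect only at larger amounts of compound and lower numbers for an effect already at smaller amounts), compound 2 stands level with compound 1 at the digits reported; the two values lie within the scatter of each other, so no order between them is claimed.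

Compound 3 is `Cc1cccc(S(=O)(=O)NCc2ccc(CNC(=O)c3ccccc3C)cc2)c1`. It differs from compound 2 by 3-methylphenyl in place of 4-fluorophenyl on a sulfonyl sulfur. Compound 1 already carries 3-methylphenyl on its sulfonyl sulfur, and in this assay compound 1 gives 10 nM, the same figure as compound 2.

On that basis no step beyond the scatter is expected, so the step of no change at the digits printed from compound 2 to compound 3 (within the scatter) is expected to be flat. Compound 3 is therefore estimated at 10 nM, with a range from 4 nM to 25 nM.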

Compound 3, effective concentration (reported as EC, without a stated level of effect): 1000 nM
For compound 3 the middle estimate is 100-fold (2.00 log units) below the measured one; the measured number lies above the stated range.
By their numbers in this assay, from the lowest: compounds 1 and 2 (each within the scatter of the next); then compound 3.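

In this assay the two places do not act independently. 3-Methylphenyl in place of 4-fluorophenyl on the sulfonyl sulfur gives a 100-fold higher number from compound 2 to compound 3 (2.00 log units; beyond the scatter), although compound 1 carries that same group at 10 nM, and with 3-methylphenyl held on the sulfur, 2-methylphenyl in place of pyridin-3-yl on the carbonyl carbon gives a 100-fold higher number from compound 1 to compound 3 (2.00 log units; beyond the scatter). Nothing available explains this dependence.

Still open, as far as these compounds go, is how pyridin-3-yl on the carbonyl carbon behaves with 4-fluorophenyl on the sulfonyl sulfur. Also open, from the compounds shown here alone, is what an amine or a carboxylic acid would do on the sulfonyl sulfur's aryl group.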